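The source may hold more compounds than are shown below. What is called first, only, known or untested is meant among the compounds shown, and "the series" means these compounds.

Three compounds have been measured in a functional assay on PC-3 cells (Homo sapiens) for cytotoxicity, read by sulforhodamine B assay; a higher number here means a weaker inhibitor of growth, a lower number a stronger inhibitor of growth:
compound 1 `COc1cccc(OC)c1OCCNCCOc1ccccc1OCc1cccc(C)c1` gives 32300 nM;
compound 2 `COc1cccc(OC)c1OCCNCCOc1ccccc1OCc1ccc(C)cc1` gives 27500 nM;
compound 3 `COc1cccc(OC)c1OCCNCCOc1ccccc1OCc1cccc([N+](=O)[O-])c1` gives 38900 nM.

Compound 3 has the highest of the three numbers, but the gaps to the others are small: a 1.2-fold higher number from compound 1 to compound 3 (0.08 log units; within the scatter) and a 1.4-fold higher number from compound 2 to compound 3 (0.15 log units; within the scatter), both within the scatter. Compound 4 `COc1cccc(OC)c1OCCNCCOc1ccccc1OCc1ccc([N+](=O)[O-])cc1` has not been measured. It differs from compound 3 in one place: 4-nitrophenyl in place of 3-nitrophenyl on a saturated chain carbon bound to an oxygen on an aromatic ring. For the measured compounds named here, the closest precedent is the analogous change from 3-methylphenyl to 4-methylphenyl, a 1.2-fold lower number from compound 1 to compound 2 (0.07 log units; within the scatter), which stayed within the scatter. On that basis the step in this assay is expected to be no larger than the scatter, in either direction: a 1.1-fold lower number from compound 3 to compound 4 (0.05 log units; within the scatter). Compound 4 is therefore estimated at 35000 nM, with a plausible range from 17000 nM to 70000 nM.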

Compound 4, concentration for total growth inhibition: 43600 nM
Estimate against measurement, compound 4: 1.2-fold (0.10 log units) below, and the stated range covers the measured number.
By their numbers in this assay, from the lowest: compounds 2, 1, 3 and 4 (each within the scatter of the next).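

In this assay, the nitro group's move from 3-nitrophenyl to 4-nitrophenyl stays within the scatter, a 1.1-fold higher number from compound 3 to compound 4 (0.05 log units; within the scatter), so this position change now reads the same with nitro as with methyl. Replacing methyl with nitro also stays within the scatter, both with the position kept, a 1.6-fold higher number from compound 2 to compound 4 (0.20 log units; within the scatter), and with it altered, a 1.3-fold higher number from compound 1 to compound 4 (0.13 log units; within the scatter). The methyl-to-nitro change can now be read twice, and the two readings agree: the same change on two cores in this assay, a 1.2-fold higher number (0.08 log units; within the scatter) from compound 1 to compound 3 and a 1.6-fold higher number (0.20 log units; within the scatter) from compound 2 to compound 4, 1.3-fold (0.12 log units) apart, within the scatter of two such steps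

Going by these compounds, all four compounds carry methyl or nitro on this phenyl ring, so whether any group here can shift the number beyond the scatter remains open. An amine or a carboxylic acid in that place would put this to the test.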